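Acyl chain shortening at the amide of an aminoketone series

A few compounds are considered here, and "the series" means these few. Any claim that something is new, unique, unknown or untested is made for them only; others in the source may bear on it.

Among the measured compounds shown here, compound 1 `CCC(=O)NCCC(=O)c1cc(OC)ccc1N` and compound 2 `COc1ccc(N)c(C(=O)CCNC(=O)C2CC2)c1` are the two measured members. In a functional assay for inhibition of kynurenine 3-monooxygenase (Rattus norvegicus), tested at 1 mM (on this read-out higher numbers stand for more inhibition at the one concentration tested (going by the name of the read-out) and lower numbers for less inhibition), compound 1 gives 99.4%, and compound 2 gives 99.9%; the step of a number 0.5 percentage points higher from compound 1 to compound 2 (within the scatter) shows that a cyclopropyl in place of ethyl on the carbonyl carbon leaves the read-out unchanged. Compound 3 `COc1ccc(N)c(C(=O)CCNC(C)=O)c1` differs from compound 1 by hydrogen in place of methyl on a saturated chain carbon bound to a carbonyl carbon. For the measured compounds named here, no measured step touches this exact change, but the one step on the same carbonyl carbon was flat, so no step beyond the scatter is expected in this assay for compound 3, estimated at 98% (90% to 100%), a step of a number 1.4 percentage points lower from compound 1 to compound 3 (within the scatter).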

Compound 3, a percentage reported as inhibition, at one concentration (the size of the read-out at that concentration, not a potency): 102%
Compound 3: the middle estimate sits 4 percentage points below what was measured, and the stated range ends below it.
By their numbers in this assay, from the lowest: compounds 1, 2 and 3 (each within the scatter of the next).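

In this assay, the step to acetamido reads a number 2.6 percentage points higher from compound 1 to compound 3 (within the scatter), and methyl in place of cyclopropyl on the carbonyl carbon reads a number 2.1 percentage points higher from compound 2 to compound 3 (within the scatter), so methyl, ethyl and cyclopropyl on this carbonyl carbon now form a flat set. At the single concentration tested, this read-out separates none of the three compounds. No evidence on the origin of this flatness is available.

Still open, as far as these compounds go, is whether a longer chain, a phenyl ring or a carboxylic acid on this carbonyl carbon would hold the read-out. Also open, from the compounds shown here alone, is how the three compounds would rank at lower concentrations.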